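The compounds below may be only part of what the source reports. "The series", "measured", "known", "first", "only" and "open" are said of these compounds alone.

In a physicochemical assay for solubility, read by HPLC, with a stated time of 24 h (on this read-out lower numbers stand for lower solubility and higher numbers for higher solubility), compound 1 (`COC(=O)CC1CCN(C[C@H]2CN(c3ccc(-n4cc(-c5ccccn5)cn4)c(F)c3)C(=O)O2)CC1`) gives 92100 nM, the higher of the two actual numbers available. The other number comes from compound 3 (`COC[C@H]1CN(c2ccc(-n3cc(-c4ccccn4)cn3)c(F)c2)C(=O)O1`), which gives 36200 nM. Compound 2 (`O=C(OC[C@H]1CN(c2ccc(-n3cc(-c4ccccn4)cn3)c(F)c2)C(=O)O1)c1ccccc1`) gives <= 65400 nM, and this is a limit of the assay rather than a number.

Compound 4 (`O=C1O[C@@H](Cn2ccnc2)CN1c1ccc(-n2cc(-c3ccccn3)cn2)c(F)c1`) has not yet been measured. It keeps the core of compound 1 and changes one group: 1H-imidazol-1-yl in place of 4-((methoxycarbonyl)methyl)piperidin-1-yl on a saturated chain carbon bound to a saturated ring carbon.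

The same piperidinyl group has been replaced in two measured steps. Putting benzoyloxy in its place gives an at least 1.4-fold lower number from compound 1 to compound 2 (0.14 log units; that floor lies within the scatter), so only a floor is known for the size of that step. Putting methoxy in its place gives a 2.5-fold lower number from compound 1 to compound 3 (0.41 log units; beyond the scatter), and this is the firmer guide. Resting on that step to compound 3, a modest move to a lower number is expected for the new replacement in this assay. The estimated step is a 2.2-fold lower number from compound 1 to compound 4 (0.34 log units; beyond the scatter). Compound 4 is therefore estimated at 42000 nM, with an expected range from 15000 nM to 100000 nM.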

Compound 4, solubility: 12300 nM
Compound 4: the middle estimate sits 3.4-fold (0.53 log units) above what was measured; measured number outside the range, below it.
By their numbers in this assay, from the lowest: compound 4; then compound 3; then compound 1.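

In this assay, the group on this saturated chain carbon turns out to matter more than the methoxy step alone could show: 1H-imidazol-1-yl in place of 4-((methoxycarbonyl)methyl)piperidin-1-yl gives a 7.5-fold lower number from compound 1 to compound 4 (0.87 log units; beyond the scatter), and compound 4 now holds the lowest of the three actual numbers. The two replacements of the piperidinyl group also differ from each other, with a 2.9-fold lower number from compound 3 to compound 4 (0.47 log units; beyond the scatter), so the position does more than set compound 1 apart from everything else. The step between compound 2 and compound 4 cannot be read, because compound 2 gives a limit and not a number: the limit of <= 65400 nM in this assay, at which 1 of the 4 values shown sits.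

Still open, on these data alone, is how a carboxylic acid in place of the methyl ester of compound 1 would read in this assay, or a plain piperidin-1-yl group without the ester side chain, either of which would help show which part of that group goes with the high number. Also open, as far as these compounds go, is whether another five-membered aromatic ring, such as 1H-1,2,3-triazol-1-yl, would read as low as compound 4, or whether that low number belongs to the imidazole alone.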